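Removing the ring methyl from compound 3

The source may report more compounds than this note shows. Statements on the series, on what has been measured and on what is new or still open speak of the compounds shown alone.

Going by the values given here, compound 3 `Cc1cc(C(F)(F)F)c(S(C)(=O)=O)cc1C(=O)N=C(N)N` gives 37 nM in a functional assay for inhibition of sodium/hydrogen exchanger (Oryctolagus cuniculus) (a lower number here means a stronger inhibitor, a higher number a weaker inhibitor), the lowest of the three numbers measured so far. Compound 1 `Cc1ccc(-c2ccc(C(=O)N=C(N)N)cc2S(C)(=O)=O)cc1` gives 100 nM and compound 2 `CS(=O)(=O)c1cc(C(=O)N=C(N)N)ccc1C#N` gives 140 nM. Among the compounds with values here, the only single-place step measured, a 1.4-fold higher number from compound 1 to compound 2 (0.15 log units; within the scatter), concerns a different change and does not bear on the step considered here. Compound 4 `CS(=O)(=O)c1cc(C(=O)N=C(N)N)ccc1C(F)(F)F` differs from compound 3 by hydrogen in place of methyl on an aromatic carbon. Within the data shown here, no measured pair removes a ring methyl, so the expected step is set close to nothing: a 1.6-fold higher number from compound 3 to compound 4 (0.21 log units; within the scatter) is expected, with a modestly higher number judged somewhat more likely than a lower one. Compound 4 is estimated at 60 nM, within the range 25 nM to 150 nM.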

Compound 4, half-maximal inhibitory concentration: 140 nM
For compound 4 the middle estimate is 2.3-fold (0.37 log units) below the measured one, within the range that was stated.
By their numbers in this assay, from the lowest: compound 3; then compounds 1, 2 and 4 (each within the scatter of the next).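

In this assay, going by these compounds alone, the ring methyl counts at this position: a 3.8-fold higher number from compound 3 to compound 4 (0.58 log units; beyond the scatter), the first single-place step beyond the scatter. Without that methyl, the other position does not separate the compounds: trifluoromethyl in place of cyano gives no change at the digits printed from compound 2 to compound 4 (within the scatter), and trifluoromethyl in place of 4-methylphenyl gives a 1.4-fold higher number from compound 1 to compound 4 (0.15 log units; within the scatter). No measured property is available to account for the methyl step.

As far as these compounds go, whether an ethyl or methoxy group at the methyl position would match compound 3 remains open. So does whether the methyl step carries over when cyano or 4-methylphenyl replaces trifluoromethyl.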